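Removing One Methyl from a Potent Somatostatin Agonist

A few compounds are considered here, and "the series" means these few. Any claim that something is new, unique, unknown or untested is made for them only; others in the source may bear on it.

Measured compounds in a functional assay on CHO-K1 cells for agonist activity at somatostatin receptor type 2 (Homo sapiens), read by cAMP accumulation, with a stated time of 30 min; on this read-out higher numbers stand for an effect only at larger amounts of compound and lower numbers for an effect already at smaller amounts:
compound 1 `Cc1cc(C)cc(-c2cncc(-c3nc4cc(C)cc(C)c4[nH]3)c2N2CCC(N)CC2)c1` gives 0.013 nM
compound 2 `Cc1cc(C)cc(C(=O)Nc2cncc(-c3cc(C)cc(C)c3)c2N2CCC(N)CC2)c1` gives 0.04 nM

Compound 1 has the lowest number of the two, and compound 2 sits beyond the scatter above it. Compound 3 `Cc1cc(C)cc(-c2cncc(-c3nc4cc(C)ccc4[nH]3)c2N2CCC(N)CC2)c1` differs from compound 1 by hydrogen in place of methyl on an aromatic carbon, the carbon in question being part of a fused system of two rings. Within the data shown here, no measured pair shows such a change, so the outcome is uncertain; a small step toward a higher number, or none beyond the scatter, seems most likely. Compound 3 is expected to give about 0.025 nM, with a range from 0.008 nM to 0.08 nM. This estimate means a step of a 1.9-fold higher number from compound 1 to compound 3 (0.28 log units; within the scatter), expected to stay within the scatter.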

Compound 3, half-maximal effective concentration: 0.013 nM
Compound 3: middle estimate off by 1.9-fold (0.28 log units), on the high side; the measured number falls inside the stated range.
By their numbers in this assay, from the lowest: compounds 1 and 3 (each within the scatter of the next); then compound 2.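

In this assay, putting hydrogen in place of this methyl on an aromatic carbon of the fused system of two rings gives no change at the digits printed from compound 1 to compound 3 (within the scatter) and shows that the low number of compound 1 does not depend on this methyl. This carbon therefore accepts the smaller substituent in this assay. Nothing available explains this result.

From the compounds shown here alone, whether a larger group, such as methoxy or an amine, would be accepted at this carbon stays open. So does the role of the methyl that remains on this ring in compound 3.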